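The source may hold more compounds than are shown below. What is called first, only, known or untested is meant among the compounds shown, and "the series" means these compounds.

Working notes on a small sulfonamide series.

Compound 1 `Cc1cc(CNS(=O)(=O)c2ccc(Cl)cc2)c(C)s1` and compound 2 `Cc1cc(CNS(=O)(=O)c2ccc(Br)cc2)c(C)s1` share one core; compound 3 `O=S(=O)(NCc1csc2ccccc12)c1ccc(Cl)cc1` and compound 4 `O=S(=O)(NCc1csc2ccccc12)c1ccc(Br)cc1` share another. The difference between the two cores is not broken down here. In an ADME assay on MDCK cells (Canis lupus familiaris) for cytotoxicity, read by MTT assay, with a stated time of 24 h (on this read-out lower numbers stand for higher toxicity in this test and higher numbers for lower toxicity in this test), compound 1 gives 52900 nM, and compound 2 gives 56400 nM. Compound 3 gives 69600 nM in this assay; its numbers and those of compound 1 and compound 2 all sit within the scatter of one another, so no order among the three can be read from them.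

Within the data shown here, the one measured pair that differs in a single place is a 1.1-fold higher number from compound 1 to compound 2 (0.03 log units; within the scatter); the change is bromo in place of chloro on an aromatic carbon. The same kind of change carries compound 3 to compound 4: bromo in place of chloro on an aromatic carbon. The two place descriptions agree word for word, so the surroundings of the exchanged atom are described alike in both pairs.

Since the halogen swap in the measured pair barely moved the number in this assay, an equally small step is expected for the new pair, namely a 1.1-fold higher number from compound 3 to compound 4 (0.03 log units; within the scatter), resting on the step from compound 1 to compound 2 and on the value of compound 3, 69600 nM. Compound 4 is therefore estimated at 75000 nM in this assay, with a plausible span from 40000 nM to 140000 nM. The measurement will show whether the swap is as quiet on this core as on the first.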

Compound 4, half-maximal cytotoxic concentration: 87100 nM
Compound 4: the middle estimate sits 1.2-fold (0.06 log units) below what was measured; the range from low to high includes it.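

In this assay the exchange of chloro for bromo on the second core reads a 1.3-fold higher number from compound 3 to compound 4 (0.10 log units; within the scatter) and, like the step on the first core, does not stand clear of the scatter. The 4-chlorophenyl to 4-bromophenyl change therefore carries from one core to the other as a quiet step, and the two steps agree as far as repeated measurements of this kind allow: the same change on two cores in this assay, a 1.1-fold higher number (0.03 log units; within the scatter) from compound 1 to compound 2 and a 1.3-fold higher number (0.10 log units; within the scatter) from compound 3 to compound 4, 1.2-fold (0.07 log units) apart, within the scatter of two such steps. This holds only for these two pairs and this read-out; it does not show that chloro and bromo are interchangeable on other cores or in other assays, and with both steps inside the scatter, a small real effect of the exchange can be neither claimed nor excluded.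

The compounds shown leave open whether anything other than these two halogens at that place on the aromatic ring, such as a nitrile, a methoxy group or an amine, would move the number at all. They also leave open what a carboxylic acid or a longer chain on either core would do, and how much each separate feature of the two cores contributes.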